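This account rests on a few compounds, and the source may have more. Where it says the series, first, only, none or still open, it means among the compounds named here.

Of the compounds shown here, three of a shared core have been tested in a functional assay on HEL cells (Homo sapiens) for cytotoxicity, read by microscopy; a lower number here means that less compound is tolerated, a higher number that more compound is tolerated. Compound 1 `Cc1cn([C@@H]2O[C@H](CO[Si](C)(C)C(C)(C)C)[C@@]3(OS(=O)(=O)C=C3NCC(N)=O)[C@H]2O[Si](C)(C)C(C)(C)C)c(=O)n(C)c1=O` gives 16000 nM in this assay. Compound 2 `Cc1cn([C@@H]2O[C@@H]3COC(=O)[C@]3(OS(C)(=O)=O)[C@H]2O)c(=O)[nH]c1=O` reaches only a limit of the assay, reported as >= 400000 nM. Compound 3 `CCOC(=O)CNC(=O)NC1=CS(=O)(=O)O[C@@]12[C@@H](CO[Si](C)(C)C(C)(C)C)O[C@@H](n1cc(C)c(=O)n(C)c1=O)[C@@H]2O[Si](C)(C)C(C)(C)C` gives 16000 nM in this assay, level with compound 1 within the usual scatter of such measurements.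

For the measured compounds named here, the one step that joins measured compounds in one place runs no change at the digits printed from compound 1 to compound 3 (within the scatter), where ((ethoxycarbonyl)methyl)carbamoyl takes the place of carbamoylmethyl on an amine nitrogen. That the remaining value is a limit is recorded as the limit of >= 400000 nM in this assay, at which 1 of the 3 values shown sits.

Compound 4 `Cc1cn([C@@H]2O[C@H](CO[Si](C)(C)C(C)(C)C)[C@@]3(OS(=O)(=O)C=C3NC(=O)c3ccccc3)[C@H]2O[Si](C)(C)C(C)(C)C)c(=O)n(C)c1=O` has not yet been measured. It differs from compound 3 by phenyl in place of ((ethoxycarbonyl)methyl)amino on a carbonyl carbon. Going by the values given here, no measured step touches a carbonyl carbon in this way, so nothing among the three compounds speaks directly to it; the only step seen, from compound 1 to compound 3, stayed within the scatter, and compound 3 sits where compound 1 does. On that footing the step from compound 3 to compound 4 is expected to be no change at the digits printed from compound 3 to compound 4 (within the scatter), that is, no change beyond the scatter. Compound 4 is therefore estimated at 16000 nM in this assay, with a range from 5000 nM to 50000 nM.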

Compound 4, minimum cytotoxic concentration: >= 3200 nM
Compound 4: no number, only a limit; the forecaster's own chance of this, stated with the estimate: 10%; the middle value does not contradict the limit.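

In this assay compound 4 gives only a limit, >= 3200 nM. The steps to it from compound 1 and from compound 3 therefore cannot be read. The compounds shown leave open whether phenyl in place of ((ethoxycarbonyl)methyl)amino on a carbonyl carbon changes the tolerated concentration at all, and where compound 4 stands relative to compound 1 and compound 3.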